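Swapping the aminophenyl for a dichlorophenyl on the carbonyl

The source may hold more compounds than are shown below. What is called first, only, known or untested is meant among the compounds shown, and "the series" means these compounds.

Measured compounds:
- compound 1, `COc1cc(-c2cc(/C=C/C(=O)c3ccc(N)cc3)[nH]n2)cc(OC)c1OC`, 17500 nM
- compound 2, `COc1ccc(-c2cc(/C=C/C(=O)c3ccc(OC)c(OC)c3)[nH]n2)cc1`, 4310 nM

Both compounds were tested in a functional assay on TK-10 cells (Homo sapiens) for inhibition, read by sulforhodamine B assay, with a stated time of 48 h; on this read-out higher numbers stand for weaker inhibition of growth and lower numbers for stronger inhibition of growth. Of the two numbers available, compound 1 has the higher one, so its growth inhibition is the weaker; compound 2 lies well below it, and this gap is larger than the usual scatter. The two compounds differ in more than one place, so their values show only the gap between them and nothing more.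

Compound 3, `COc1cc(-c2cc(/C=C/C(=O)c3ccc(Cl)c(Cl)c3)[nH]n2)cc(OC)c1OC`, has not yet been measured. It differs from compound 1 in one place: 3,4-dichlorophenyl in place of 4-aminophenyl on a carbonyl carbon. The core and the rest of the molecule stay the same.

For the measured compounds named here, no measured pair records this change on its own, so the size of its effect is uncertain. A moderate move toward stronger inhibition seems the most reasonable expectation, though a step within the scatter would not surprise. The estimated step from compound 1 to compound 3 is a 1.9-fold lower number from compound 1 to compound 3 (0.29 log units; within the scatter). For compound 3 in this assay, the estimated value is 9000 nM, with a likely range from 3000 nM to 30000 nM.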

Compound 3, concentration for total growth inhibition: 43200 nM
For compound 3 the middle estimate is 4.8-fold (0.68 log units) below the measured one; measured number outside the range, above it.
By their numbers in this assay, from the lowest: compound 2; then compound 1; then compound 3.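

In this assay, putting 3,4-dichlorophenyl in place of 4-aminophenyl on the carbonyl carbon gives a 2.5-fold higher number from compound 1 to compound 3 (0.39 log units; beyond the scatter), so this change weakens growth inhibition, though only modestly. For the compounds shown here, this is the first comparison that isolates this position, and it shows that the group on the carbonyl carbon can shift the read-out beyond the usual scatter, with 4-aminophenyl the better of the two groups compared here. No measurement on hand explains the direction of this step.

The swap alters several things at once: the amine, with its hydrogen-bond donor and acceptor, leaves, and two chlorine atoms arrive, so this single step cannot show whether losing the amine, gaining the chlorines or both account for the change. As far as these compounds go, an unsubstituted phenyl or a phenyl carrying a hydroxyl group or a single chlorine on the same carbonyl carbon could help separate these contributions, and whether the step would look the same on a different core also remains open.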